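Mirror-Image Form of a Cholecystokinin Receptor Ligand

This account rests on a few compounds, and the source may have more. Where it says the series, first, only, none or still open, it means among the compounds named here.

Measured so far in an assay on brain with Gastrin/cholecystokinin type B receptor (Mus musculus) as the target, read by CCK-8 assay, at pH 7.4; a higher number here means a weaker inhibitor, a lower number a stronger inhibitor:
- compound 1, `O=C1NN(C(=S)Nc2ccc(Cl)c(C(F)(F)F)c2)C(c2ccccc2)C1c1ccccc1`, gives 880 nM
- compound 2, `O=C1NN(C(=S)Nc2ccc(Cl)c(C(F)(F)F)c2)[C@H](c2ccccc2)[C@H]1c1ccccc1`, gives 1900 nM

Compound 2 stands at the highest number of the two, so it is the weaker inhibitor of the pair; its nearest neighbour is compound 1, and the step of a 2.2-fold higher number from compound 1 to compound 2 (0.33 log units; beyond the scatter) is modest but beyond the scatter. Compound 1 is drawn without a set configuration at its two ring carbons, so it is a mixture of both mirror-image forms, whereas compound 2 is one single form; the loss of potency from compound 1 to compound 2 follows because of the fact that one of compounds 1 and 2 is drawn with a defined configuration and the other without, at the place where they differ, which means the other form must carry more of the mixture's activity.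

Compound 3, `O=C1NN(C(=S)Nc2ccc(Cl)c(C(F)(F)F)c2)[C@@H](c2ccccc2)[C@@H]1c1ccccc1`, is exactly that other form: the two compounds have the same atoms and bonds and differ only in configuration as drawn: 2 of 2 stereo elements differ (all stereocentres are inverted: mirror images); a stereocentre at a saturated ring carbon is drawn S in compound 2 and R in compound 3; a stereocentre at a saturated ring carbon is drawn R in compound 2 and S in compound 3. Going by the values given here, the only measured step that bears on it is a 2.2-fold higher number from compound 1 to compound 2 (0.33 log units; beyond the scatter), pointing the opposite way. Compound 3 is therefore expected to show a step of a 3.5-fold lower number from compound 2 to compound 3 (0.54 log units; beyond the scatter) in this assay, towards a stronger inhibitor. The estimate for compound 3 is 550 nM, with a range from 200 nM to 1500 nM.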

Compound 3, half-maximal inhibitory concentration: 550 nM
The estimate for compound 3 equals the measured number at the digits printed, within the range that was stated.
By their numbers in this assay, from the lowest: compounds 3 and 1 (each within the scatter of the next); then compound 2.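

The mirror-image pair shows that the arrangement at the two saturated ring carbons matters in this assay, with a 3.5-fold lower number from compound 2 to compound 3 (0.54 log units; beyond the scatter). Going by these compounds alone, until now, the only comparison set a single form against a drawing with no defined configuration, so the activity of the opposite form could only be inferred. The gap can be assigned to the spatial arrangement alone, because the atoms and bonds stay the same: the fact that compounds 2 and 3 differ only in the configuration as drawn

Compound 3 also cannot be told apart from the undefined compound 1, with a 1.6-fold lower number from compound 1 to compound 3 (0.20 log units; within the scatter), so separating out this form brings no clear gain in this assay over compound 1, whereas compound 2 falls measurably behind it.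

The compounds shown leave open whether the preference for the arrangement in compound 3 would survive a change elsewhere in the molecule, such as a carboxylic acid on one of the phenyl rings or an amine in place of the chloro group. They also leave open how the forms with the opposite relative arrangement of the two ring carbons, where one centre is inverted and the other kept, would compare with compound 3.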